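Notes on the terminal anilide of the series

This account rests on a few compounds, and the source may have more. Where it says the series, first, only, none or still open, it means among the compounds named here.

Of the compounds shown here, three on the shared core have been measured. In a functional assay on NCI-H460 cells (Homo sapiens) for inhibition, read by CCK-8 assay, with a stated time of 72 h, tested at 1 uM (on this read-out lower numbers stand for less inhibition of growth and higher numbers for more inhibition of growth at the one concentration tested), compound 1 `CN(C)C(=O)c1cc2cnc(Nc3ccc(NC(=O)C4(C(=O)Nc5ccccc5)CC4)cc3)nc2n1C1CCCC1` gives 42.4%. Within the data shown here, compound 2 `CN(C)C(=O)c1cc2cnc(Nc3ccc(NC(=O)C4(C(=O)Nc5cccc(O)c5)CC4)cc3)nc2n1C1CCCC1` gives 75.5% in this assay, the highest of the three numbers; the one single-change step measured, a number 33.1 percentage points higher from compound 1 to compound 2 (beyond the scatter), is the hydroxy in place of hydrogen on an aromatic carbon. Compound 3 `CN(C)C(=O)c1cc2cnc(Nc3ccc(NC(=O)C4(C(=O)Nc5ccc(F)cc5)CC4)cc3F)nc2n1C1CCCC1` gives 11.9%, the lowest number, but it differs from compound 1 and from compound 2 in two places at once, so only its value itself stands beside theirs.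

Compound 4 `CN(C)C(=O)c1cc2cnc(Nc3ccc(NC(=O)C4(C(=O)Nc5ccc(Cl)c(C(F)(F)F)c5)CC4)cc3)nc2n1C1CCCC1` is the next step from compound 2: 4-chloro-3-(trifluoromethyl)phenyl in place of 3-hydroxyphenyl on an amide-type nitrogen. Read backwards, a number 33.1 percentage points higher from compound 1 to compound 2 (beyond the scatter) bears on it: the hydroxy group that brought the large rise now leaves, and the entering 4-chloro-3-(trifluoromethyl)phenyl carries no donor or acceptor in its place. Among the measured compounds shown here, the chloro and trifluoromethyl groups have no measured counterpart, so their own contribution is unknown. For compound 4 a downward step beyond the scatter is therefore expected, a number 37.5 percentage points lower from compound 2 to compound 4 (beyond the scatter), landing in the region where compound 1 sits. Compound 4 is estimated at 38% in this assay, with a range of 12% to 62%.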

Compound 4, percent growth inhibition at one concentration: 2.1%
Compound 4: middle estimate off by 35.9 percentage points, on the high side; measured number outside the range, below it.
By their numbers in this assay, from the lowest: compounds 4 and 3 (each within the scatter of the next); then compound 1; then compound 2.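

The terminal aryl group on the amide-type nitrogen now has three measured forms on the shared core, and in this assay the 4-chloro-3-(trifluoromethyl)phenyl group gives a number 73.4 percentage points lower from compound 2 to compound 4 (beyond the scatter) and a number 40.3 percentage points lower from compound 1 to compound 4 (beyond the scatter). Among these compounds, the second step adds what the earlier compounds could not show: the change does more than undo the gain from the hydroxy, since compound 4 falls well under the plain phenyl of compound 1, so substitution on this ring can move the number down as well as up, and by a large step in each case. No measurement shown gives a reason for either step.

The chloro and trifluoromethyl groups enter together in compound 4, so the compounds shown leave open whether one of them alone accounts for the fall, and whether either would still lower the number with the hydroxy kept on the ring. Also open, as far as these compounds go, is whether the rise seen with the hydroxy is particular to that group or would carry over to an amine or a carboxylic acid in its place.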